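This account rests on a few compounds, and the source may have more. Where it says the series, first, only, none or still open, it means among the compounds named here.

Measured compounds:
- compound 1, `Cc1ccc(-c2nc3ccc(Br)cn3c2/C=N/OCc2cn(Cc3ccc(C#N)cc3)nn2)cc1`, 40 mg/kg in a functional assay on the whole organism (strain NMRI) with Mus musculus as the target, with a stated time of 0.5 h; on this read-out lower numbers stand for an effect already at smaller amounts and higher numbers for an effect only at larger amounts of compound
- compound 2, `O=[N+]([O-])c1ccc(Cn2cc(CO/N=C/c3c(-c4ccccc4)nc4ccc(Br)cn34)nn2)cc1`, 20 mg/kg in this assay

Compound 2 has the lowest of the two numbers in this assay, yet compound 1 lies only a small step away from it, and that gap is within the usual scatter of repeated measurements. So the two measured compounds cannot be told apart on these numbers; neither can be called the more effective one.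

Compound 3, `N#Cc1ccc(Cn2cc(CO/N=C/c3c(-c4ccccc4)nc4ccc(Br)cn34)nn2)cc1`, has not yet been measured in this assay. It is compound 2 with a single change: cyano in place of nitro on an aromatic carbon. Everything else in the molecule, including the shared core, stays as it is in compound 2.

Going by the values given here, no step between two measured compounds isolates this change, so there is no directly comparable precedent. Compound 1 also carries a cyano group at this place, with a different substituent on the core, and its number sits within the scatter of compound 2. On that basis no shift beyond the scatter is expected, and the estimated step is a 1.5-fold higher number from compound 2 to compound 3 (0.18 log units; within the scatter). Compound 3 is therefore expected to give about 30 mg/kg in this assay, most likely between 15 mg/kg and 80 mg/kg.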

Compound 3, minimum effective dose: 20 mg/kg
Estimate against measurement, compound 3: 1.5-fold (0.18 log units) above; low and high end bracket the measured number.
By their numbers in this assay, from the lowest: compounds 2, 3 and 1 (each within the scatter of the next).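

In this assay, going by these compounds alone, compound 3 gives the first direct comparison of nitro and cyano on an aromatic carbon para to a large group, with everything else in the molecule held constant: this swap gives no change at the digits printed from compound 2 to compound 3 (within the scatter) and shows that, on this read-out, the two groups cannot be told apart at this place. Compound 3 also links compound 1 to the series through one change, hydrogen in place of methyl on an aromatic carbon, which gives a 2.0-fold lower number from compound 1 to compound 3 (0.30 log units; within the scatter) and so does not separate these two compounds either. Nothing available explains why neither change moves the number beyond the scatter.

As far as these compounds go, with only nitro and cyano seen at the para place, it stays open how a compound with an amine or a carboxylic acid there would read, and whether such a group would move the number beyond the scatter. From the compounds shown here alone, it also stays open how a longer chain, such as ethyl or propyl, would read in place of the methyl of compound 1.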